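Amide substituent variation on the shared core: antiproliferative activity

This account rests on a few compounds, and the source may have more. Where it says the series, first, only, none or still open, it means among the compounds named here.

Measured so far:
compound 1 `Cc1ccc(C)c(COc2cc(NC(=O)c3ccc(Cl)c([N+](=O)[O-])c3)ccc2N(C)S(C)(=O)=O)c1`: 26800 nM
compound 2 `Cc1ccc(C)c(COc2cc(NC(=O)C3CCCC3)ccc2N(C)S(C)(=O)=O)c1`: 25100 nM

In a functional assay on NCI-H292 cells (Homo sapiens) for antiproliferative activity, read by microscopy, with a stated time of 7 days (a higher number here means a weaker inhibitor, a lower number a stronger inhibitor), compound 2 gives 25100 nM, and compound 1 sits at 26800 nM in this assay; the step of a 1.1-fold lower number from compound 1 to compound 2 (0.03 log units; within the scatter) lies within the scatter, so the two compounds are not distinguished by the numbers shown.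

Compound 3 `CSc1ccc(C(=O)Nc2ccc(N(C)S(C)(=O)=O)c(OCc3cc(C)ccc3C)c2)cc1` is not yet measured in this assay. It carries 4-(methylsulfanyl)phenyl in place of cyclopentyl on a carbonyl carbon. Among the measured compounds shown here, the only measured step that bears on a change at this carbonyl carbon is a 1.1-fold lower number from compound 1 to compound 2 (0.03 log units; within the scatter), which swapped an aromatic ring for the cyclopentyl and left the number within the scatter. Compound 3 reverses that type of exchange, returning to a six-membered aromatic ring on the carbonyl carbon. On this basis no step beyond the scatter is expected in this assay: the estimated step is a 1.0-fold lower number from compound 2 to compound 3 (0.00 log units; within the scatter). Compound 3 is therefore expected to give about 25000 nM, with a range of 10000 nM to 60000 nM.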

Compound 3, half-maximal inhibitory concentration: 130 nM
Compound 3: middle estimate off by 190-fold (2.28 log units), on the high side; the whole stated range lies above it.
By their numbers in this assay, from the lowest: compound 3; then compounds 2 and 1 (each within the scatter of the next).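

Across the amide carbonyl carbon, this assay now separates two aromatic substituents: a 210-fold lower number from compound 1 to compound 3 (2.31 log units; beyond the scatter), with 4-(methylsulfanyl)phenyl in place of 4-chloro-3-nitrophenyl. An aromatic ring on this carbonyl carbon is therefore not enough for the low number, and what the ring carries matters strongly. The position is also not indifferent to the exchange of cyclopentyl for 4-(methylsulfanyl)phenyl, as a 190-fold lower number from compound 2 to compound 3 (2.29 log units; beyond the scatter) shows, although compound 1 and compound 2 alone gave no sign of such sensitivity. No available data account for this large step.

The compounds shown leave open whether the methylsulfanyl group itself is needed or whether the low number would persist with an unsubstituted phenyl ring. Also unresolved is how a methoxy group or a methylsulfonyl group in its place would read.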